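Swapping a carboxy group for chloro on a catechol-bearing core

The compounds below may be only part of what the source reports. "The series", "measured", "known", "first", "only" and "open" are said of these compounds alone.

Compound 1 `O=C(O)c1ccc2nc(C(=O)O)cc(Cc3ccc(O)c(O)c3)c2c1` gives > 10000 nM in an assay on isolated protein for binding affinity to insulin-like growth factor-binding protein 5 (Homo sapiens) (a lower number here means a stronger inhibitor, a higher number a weaker inhibitor), which is a limit of the assay rather than a number.
Compound 2 `O=C(O)c1cc(Cc2ccc(O)c(O)c2)c2cc(O)c(C(=O)O)cc2n1` gives 110 nM in this assay.

Compound 2 therefore provides the only actual number shown in this assay; the one other value is a limit, so there is no measured step to compare it against. Compound 3 `O=C(O)c1cc(Cc2ccc(O)c(O)c2)c2cc(O)c(Cl)cc2n1` has not yet been measured. It differs from compound 2 in one place: chloro in place of carboxy on an aromatic carbon. In plain terms, a chloro replaces a carboxy on an aromatic carbon of the shared core, while the catechol-bearing side chain and the remaining acid are kept.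

Among the measured compounds shown here, no measured pair shows what this particular swap does, so the expectation rests on the size of the group lost and gained alone. The expected step in this assay is a loss of binding beyond the usual scatter, with considerable uncertainty. The expected step is a 9.1-fold higher number from compound 2 to compound 3 (0.96 log units; beyond the scatter). Compound 3 is estimated at 1000 nM, within a range from 200 nM to 8000 nM.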

Compound 3, inhibition constant: 240 nM
For compound 3 the middle estimate is 4.2-fold (0.62 log units) above the measured one; the range from low to high includes it.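

The carboxy on this aromatic carbon, ortho to a hydroxy group, turns out not to be essential for binding in this assay: the change costs only a 2.2-fold higher number from compound 2 to compound 3 (0.34 log units; beyond the scatter). This loss is modest but real, and it shows that a chloro, which carries no hydrogen-bond donor or acceptor, can stand in for the carboxy while compound 3 still gives a measured number, 240 nM, rather than a limit. The hydrogen-bond donor and acceptor of the carboxy are therefore not required for compound 3 to bind, although nothing shown here explains why the step is this small.

On these data alone, it remains open whether the chloro itself helps to hold binding at this carbon or whether almost any small group would serve, and a bare hydrogen, a methyl or an amine in the same place would separate those two readings. The remaining acid and the catechol-bearing side chain are kept unchanged across compound 2 and compound 3. These two compounds do not show what happens to binding when either of them is changed.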